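The source may report more compounds than this note shows. Statements on the series, on what has been measured and on what is new or still open speak of the compounds shown alone.

Compound 1 `COc1ccc(C(=O)c2ccc(OC)c3c2C=CC(C)(C)O3)c(NC(=O)CO)c1`: 420 nM
Compound 2 `COc1ccc(C(=O)c2ccc3c(c2)C=CC(C)(C)O3)c(NC(=O)CO)c1`: 130 nM
Compound 3 `CNCC(=O)Nc1cc(OC)ccc1C(=O)c1ccc(OC)c2c1C=CC(C)(C)O2`: 1590 nM

These values come from a functional assay on A2780 cells (Homo sapiens) for antiproliferative activity, read by MTT assay, with a stated time of 48 h; a higher number here means a weaker inhibitor, a lower number a stronger inhibitor. Compound 2 has the lowest number of the three, and its gaps to the other two lie beyond the scatter. Compound 4 `CCNCC(=O)Nc1cc(OC)ccc1C(=O)c1ccc2c(c1)C=CC(C)(C)O2` has not yet been measured. It keeps the core of compound 2 and changes one group: ethylamino in place of hydroxy on a saturated chain carbon bound to a carbonyl carbon. In words, ethylamino stands in place of hydroxy on a saturated chain carbon bound to a carbonyl carbon.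

The closest measured change is a 3.8-fold higher number from compound 1 to compound 3 (0.58 log units; beyond the scatter). There, methylamino replaces hydroxy at the same kind of place, though on a core that is not identical to that of compound 2. Going by the values given here, no ethylamino compound has been measured, so this single step is only a rough guide. A rise of similar size is therefore expected in this assay. The estimated change is a 3.8-fold higher number from compound 2 to compound 4 (0.59 log units; beyond the scatter). The expected value for compound 4 is 500 nM, with an estimated range of 180 nM to 1500 nM.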

Compound 4, half-maximal inhibitory concentration: 2070 nM
The estimate for compound 4 lay 4.1-fold (0.62 log units) below the measured number; measured number outside the range, above it.
By their numbers in this assay, from the lowest: compound 2; then compound 1; then compounds 3 and 4 (each within the scatter of the next).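

In this assay, ethylamino in place of hydroxy on a saturated chain carbon bound to a carbonyl carbon gives a 16-fold higher number from compound 2 to compound 4 (1.20 log units; beyond the scatter), so a loss like the one seen with methylamino on the core of compound 1 also appears on the core of compound 2. This step is large, while a 3.8-fold higher number from compound 1 to compound 3 (0.58 log units; beyond the scatter) is modest, but both the core and the amine differ between the two steps, so the data cannot separate their contributions. No measurement here explains why the hydroxy compounds give the lower numbers.

As far as these compounds go, it remains open how methylamino would behave on the core of compound 2, which would isolate the effect of the core. From the compounds shown here alone, it is also open whether a simple amino group, a dimethylamino group or a methoxy group at this place would stay close to compound 2 or to compound 4.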